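Replacing a Tertiary Amine with Benzylamine on a Kinase Inhibitor

The source may report more compounds than this note shows. Statements on the series, on what has been measured and on what is new or still open speak of the compounds shown alone.

Measured in an assay for inhibition of Maternal embryonic leucine zipper kinase (Homo sapiens), read by ADP-Glo, with a stated time of 0.5 h; a lower number here means a stronger inhibitor, a higher number a weaker inhibitor:
compound 1, `CC(C)Nc1sc(C(=O)c2cc(Br)cs2)c(N)c1C#N`, gives 599 nM.
compound 2, `COc1ccc(C(=O)c2sc3nc(C)ccc3c2N)cc1OC`, gives > 5000 nM, which is a limit of the assay rather than a number.
compound 3, `CC(C)N(C)c1sc(C(=O)c2ccc(Cl)s2)c(N)c1C#N`, gives 1420 nM.

Among the two numbers, compound 3 stands highest, with compound 1 the nearest at a lower value beyond the scatter. Compound 4, `N#Cc1c(NCc2ccccc2)sc(C(=O)c2ccc(Cl)s2)c1N`, has not yet been measured in this assay. It differs from compound 3 in one place: benzylamino in place of isopropyl(methyl)amino on an aromatic carbon. Within the data shown here, no step between measured compounds is available to set the size of this change, so the expectation is a small shift toward a lower number, of a size that may not exceed the scatter. Compound 4 is expected to give 600 nM, within a range from 180 nM to 2000 nM. That estimate implies the expected step of a 2.4-fold lower number from compound 3 to compound 4 (0.37 log units; beyond the scatter).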

Compound 4, half-maximal inhibitory concentration: > 5000 nM
Compound 4 ended at the assay's limit; the forecaster's own chance of this, stated with the estimate: 5%; middle value at least 8.3-fold (0.92 log units) from the limit.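

At this position, the aromatic carbon next to the ring sulfur, the amino group matters: benzylamino in place of isopropyl(methyl)amino gives an at least 3.5-fold higher number from compound 3 to compound 4 (0.54 log units; beyond the scatter) in this assay. Compound 4 gives > 5000 nM, which is a limit of the assay and not a number. The step is therefore only a lower bound on the loss, and its true size cannot be read: the limit of > 5000 nM in this assay, at which 2 of the 4 values shown sit.

The compounds shown do not separate the aromatic ring of benzylamino from its hydrogen-bond donor. From the compounds shown here alone, how a morpholine or a phenethylamino group would fare at this position also remains open.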